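This account rests on a few compounds, and the source may have more. Where it says the series, first, only, none or still open, it means among the compounds named here.

Measured in a functional assay on MCF7 cells (Homo sapiens) for antiproliferative activity, read by MTT assay; a lower number here means a stronger inhibitor, a higher number a weaker inhibitor:
- Compound 1 `CCCC/C=C\CCCCCCCCCc1cc(=O)c2c(O)cc(OCOC)cc2o1`: > 67200 nM (a limit)
- Compound 2 `CC/C=C\C/C=C\C/C=C\CCCCCCCc1cc(=O)c2c(O)cc(OCOC)c(C)c2o1`: 17500 nM
- Compound 3 `CC/C=C\C/C=C\C/C=C\CCCCCCCc1cc(=O)c2c(O)cc(O)cc2o1`: 17500 nM

Compound 3 gives 17500 nM in this assay, and it stands level with compound 2 at the digits shown. Compound 1 gives only a limit, > 67200 nM.

Compound 4 `CC/C=C\C/C=C\C/C=C\CCCCCCCc1cc(=O)c2c(O)cc(OCOC)cc2o1` is the next to be considered. It is compound 3 with methoxymethyl in place of hydrogen on an oxygen on an aromatic ring, which turns hydroxy into methoxymethoxy: methoxymethyl in place of hydrogen on an oxygen on an aromatic ring.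

Within the data shown here, no measured pair shows this change on its own, so the expectation rests on the values alone. Compound 2 already bears methoxymethoxy and gives 17500 nM, the same reading as the hydroxy compound 3. Compound 1 also bears methoxymethoxy, and its result is the limit > 67200 nM. A small step in this assay is therefore expected, either none beyond the scatter or a modest one towards weaker inhibition, and a result reported only as a limit remains possible.

The expected change is an estimated 1.4-fold higher number from compound 3 to compound 4 (0.15 log units; within the scatter). For compound 4 the estimated value is 25000 nM, with an expected range from 11000 nM to 70000 nM.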

Compound 4, half-maximal inhibitory concentration: 17500 nM
For compound 4 the middle estimate is 1.4-fold (0.15 log units) above the measured one; the measured number falls inside the stated range.
By their numbers in this assay, from the lowest: compounds 2, 3 and 4 (each within the scatter of the next). At a limit, above all of these: compound 1.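

In this assay, methoxymethyl in place of hydrogen on an oxygen on an aromatic ring gives no change at the digits printed from compound 3 to compound 4 (within the scatter), so hydroxy to methoxymethoxy is now seen as a single change, and it leaves the reading where it was. The methyl on the aromatic carbon can be read in the same way: hydrogen in place of that methyl gives no change at the digits printed from compound 2 to compound 4 (within the scatter), again with no movement in the number. The one change here that lies beyond the scatter is in the chain, where a group of 10 heavy atoms in place of a group of 8 heavy atoms, on a saturated chain carbon seven bonds along the chain from an aromatic carbon, gives an at least 3.8-fold lower number from compound 1 to compound 4 (0.58 log units; beyond the scatter), and the size of that step is only a bound, set by the reading for compound 1: the limit of > 67200 nM in this assay, at which 1 of the 4 values shown sits.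

The compounds shown leave open whether another group on that oxygen, such as benzyl or a chain ending in an amine, would also leave the number in place. They also leave open how the number moves along the chain itself, for instance with a longer chain or one ending in a carboxylic acid.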